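The source may hold more compounds than are shown below. What is called first, only, known or untested is meant among the compounds shown, and "the series" means these compounds.

Measured in a functional assay (aorta) with Rattus norvegicus as the target; a lower number here means that less compound is needed, a higher number that more compound is needed for the effect:

- Compound 1 `O=C1CCCN1C1=CC(CF)(CF)Oc2ccc([N+](=O)[O-])cc21`: 7.76 nM
- Compound 2 `N#Cc1ccc2c(c1)C(N1CCCCC1=O)=CC(CF)(CF)O2`: 162 nM

Compound 2, at 162 nM, has the higher of the two numbers, so more of it is needed for the effect. Its gap to compound 1 lies beyond the usual scatter.

Compound 3 `O=C1CCCCN1C1=CC(CF)(CF)Oc2ccc([N+](=O)[O-])cc21` is compound 2 with one change: nitro in place of cyano on an aromatic carbon. Within the data shown here, no measured pair shows this change alone, so its size cannot be read directly from the data. Compound 1, which also carries nitro, gives 7.76 nM, and this points to a moderate fall in this assay, probably beyond the scatter, though the uncertainty is wide. The estimated step is a 3.2-fold lower number from compound 2 to compound 3 (0.51 log units; beyond the scatter). For compound 3 the expected value is 50 nM, with an estimated range of 12 nM to 200 nM.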

Compound 3, half-maximal effective concentration: 17.4 nM
For compound 3 the middle estimate is 2.9-fold (0.46 log units) above the measured one; measured number inside the range.
By their numbers in this assay, from the lowest: compound 1; then compound 3; then compound 2.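

In this assay, among these compounds, with the 2-oxopiperidin-1-yl group held fixed, nitro in place of cyano on the aromatic carbon gives a 9.3-fold lower number from compound 2 to compound 3 (0.97 log units; beyond the scatter), the first direct reading of this change, and shows that this position can move the number beyond the scatter. With nitro held fixed, 2-oxopiperidin-1-yl in place of 2-oxopyrrolidin-1-yl on the double-bonded ring carbon gives a 2.2-fold higher number from compound 1 to compound 3 (0.35 log units; beyond the scatter), so this second position can also move the number beyond the scatter. Nothing measured here explains the size of either step.

From the compounds shown here alone, it remains open whether an amine or a carboxylic acid on the aromatic carbon would give a lower or higher number than nitro. Going by these compounds, it is also open whether an open-chain amide could replace either ring group on the double-bonded ring carbon, and whether the nitro step keeps its size with 2-oxopyrrolidin-1-yl in place.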